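From 2-methoxyethoxy to octyloxy on the shared core

The compounds below may be only part of what the source reports. "The series", "measured", "known", "first", "only" and "open" are said of these compounds alone.

In an ADME assay on CCRF-HSB-2 cells (Homo sapiens) for cytotoxicity, with a stated time of 7 days (on this read-out lower numbers stand for higher toxicity in this test and higher numbers for lower toxicity in this test), compound 1 `CC(C)CSc1nc(N)nc2c1ncn2/C=C1/CC1(CO)CO` gives 60000 nM as a measured number. Compound 2 `C=CCOc1nc(N)nc2c1ncn2/C=C1/CC1(CO)CO` is reported only as a limit, > 20000 nM on the same read-out. Compound 3 `COCCOc1nc(N)nc2c1ncn2/C=C1/CC1(CO)CO` is also reported only as a limit, > 20000 nM on that read-out. Its place is therefore the limit of > 20000 nM in this assay, at which 2 of the 3 values shown sit, and nothing more exact.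

Compound 4 `CCCCCCCCOc1nc(N)nc2c1ncn2/C=C1/CC1(CO)CO` carries hexyl in place of methoxy on a saturated chain carbon, two bonds along the chain from an oxygen on an aromatic ring, so that octyloxy replaces 2-methoxyethoxy. Among the measured compounds shown here, two measured steps bear on it: a step that the limit leaves unreadable from compound 1 to compound 3 together with a step that the two limits leave unreadable from compound 2 to compound 3 and neither gives a size to carry over. The structural change alone therefore suggests a modest move in this assay towards lower numbers, held only loosely. The expected change is a step that the limit leaves unreadable from compound 3 to compound 4 and its size remains uncertain. For compound 4 the estimated value is 25000 nM with an expected range from 8000 nM to 80000 nM in this test.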

Compound 4, half-maximal cytotoxic concentration: > 20000 nM
Compound 4 gave a limit, no number; the forecaster's own chance of this, stated with the estimate: 45%; the middle value does not contradict the limit.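

Among the compounds shown here, no step to compound 4 can be read from compound 1, compound 2 or compound 3, since compound 4 is reported only as a limit: the limit of > 20000 nM in this assay, at which 3 of the 4 values shown sit. The compounds shown leave open whether octyloxy, allyloxy and 2-methoxyethoxy differ at all in this cytotoxicity test.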